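The source may report more compounds than this note shows. Statements on the series, on what has been measured and on what is new or still open speak of the compounds shown alone.

For the measured compounds named here, compound 1 `CCN(Cc1cccnc1)C(=O)COc1ccc(C)cc1` is one of two compounds measured in an assay on HEK293 cells for agonist activity at transient receptor potential cation channel subfamily M member 8 (Homo sapiens), read by fluorescence and calcium flux, with a stated time of 15 min (on this read-out higher numbers stand for an effect only at larger amounts of compound and lower numbers for an effect already at smaller amounts), where compound 1 gives 15400 nM. Compound 2 `Cc1ccc(OCC(=O)N(O)Cc2cccs2)cc1` gives 8000 nM in this assay; the number for compound 1 is the larger of the two, but the gap lies within the usual scatter, so the two cannot be told apart. Compound 3 `CCN(Cc1ccccn1)C(=O)COc1ccc(C)cc1` differs from compound 1 in one place: pyridin-2-yl in place of pyridin-3-yl on a saturated chain carbon bound to an amide-type nitrogen. Going by the values given here, no measured pair shows this change, so the expected step is none beyond the scatter, in either direction: a 1.2-fold lower number from compound 1 to compound 3 (0.07 log units; within the scatter). Compound 3 is thus expected to give about 13000 nM, with a range from 4500 nM to 40000 nM.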

Compound 3, half-maximal effective concentration: 16000 nM
For compound 3 the middle estimate is 1.2-fold (0.09 log units) below the measured one, within the range that was stated.
By their numbers in this assay, from the lowest: compounds 2, 1 and 3 (each within the scatter of the next).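

Placing pyridin-2-yl in place of pyridin-3-yl on a saturated chain carbon bound to an amide-type nitrogen gives a 1.0-fold higher number from compound 1 to compound 3 (0.02 log units; within the scatter) in this assay. For the compounds shown here, at this place, then, the two pyridine groups cannot be told apart in this read-out, which is the first direct comparison at this position. No separate measurement bears on this result.

The compounds shown leave open whether any group at this place would change the number. A plain phenyl ring or pyridin-4-yl, for example, might give a clearly different value.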